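Closing the Side Chain into a Hydroxypyrrolidine

This account rests on a few compounds, and the source may have more. Where it says the series, first, only, none or still open, it means among the compounds named here.

Compound 1 `CN[C@H](C#Cc1c(F)ccc2c1/C(=C/c1[nH]ccc1OC)C(=O)N2)CO` and compound 2 `CN[C@H](C#Cc1c(F)ccc2c1/C(=C/c1[nH]ccc1OC)C(=O)N2)[C@@H](C)O` share one core and differ only by a methyl on the side chain. In a functional assay on MDA-MB-435 cells (Homo sapiens) for inhibition (on this read-out lower numbers stand for stronger inhibition and higher numbers for weaker inhibition), compound 1 gives 349 nM. In this assay compound 2 gives 358 nM. The step was a 1.0-fold higher number from compound 1 to compound 2 (0.01 log units; within the scatter), so compound 2 stands alongside compound 1, the two within the scatter. Compound 3 `COc1cc[nH]c1/C=C1\C(=O)Nc2ccc(F)c(C#C[C@@H]3C[C@@H](O)CN3)c21` carries 4-hydroxypyrrolidin-2-yl in place of 2-hydroxy-1-(methylamino)propyl on a triple-bonded carbon. Among the measured compounds shown here, no measured step covers a ring closure; the one known step, a 1.0-fold higher number from compound 1 to compound 2 (0.01 log units; within the scatter), concerns only a methyl. Compound 3 is therefore expected to show a 1.2-fold higher number from compound 2 to compound 3 (0.07 log units; within the scatter), nothing beyond the scatter. Compound 3 is estimated at 420 nM, between 130 nM and 1300 nM.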

Compound 3, half-maximal inhibitory concentration: 63 nM
Beside the measured number, compound 3's estimate is 6.7-fold (0.82 log units) above it; the whole stated range lies above it.
By their numbers in this assay, from the lowest: compound 3; then compounds 1 and 2 (each within the scatter of the next).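

Closing the side chain into the 4-hydroxypyrrolidin-2-yl ring gives in this assay a 5.7-fold lower number from compound 2 to compound 3 (0.75 log units; beyond the scatter) and, against the side chain without the methyl, a 5.5-fold lower number from compound 1 to compound 3 (0.74 log units; beyond the scatter) as well. The substituent on the triple-bonded carbon therefore does affect this read-out, which the methyl change alone, staying within the scatter, had not shown. Nothing measured here explains the gain.

Going by these compounds, what a plain pyrrolidin-2-yl without the hydroxyl, a piperidine ring or a methyl on the ring nitrogen would do at this place remains open.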